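A few compounds are considered here, and "the series" means these few. Any claim that something is new, unique, unknown or untested is made for them only; others in the source may bear on it.

Working notes on the series in an assay on isolated protein for inhibition of cytosolic endo-beta-N-acetylglucosaminidase (Homo sapiens), tested at 1000 uM; on this read-out higher numbers stand for more inhibition at the one concentration tested (going by the name of the read-out) and lower numbers for less inhibition.

Of the compounds shown here, three carry numbers so far. Compound 1 `O=C(O)[C@@H]1NCC=C[C@@H]1O` gives 14%, compound 2 `O=C(O)[C@H]1NC[C@H](O)[C@@H](O)[C@@H]1O` gives 43%, and compound 3 `O=C(O)[C@H]1NC[C@@H](O)[C@H](O)[C@@H]1O` gives 42%. Compound 1 stands lowest of the three: compound 3 is the nearest of the others and lies beyond the scatter above it, and compound 2 lies a little further above, also beyond the scatter. Between compounds 2 and 3 the step is a number 1 percentage points lower from compound 2 to compound 3 (within the scatter), and the only difference between them is the fact that compounds 2 and 3 differ only in the configuration as drawn.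

The compound to be measured next is compound 4 `O=C(O)[C@H]1NCC=C[C@@H]1O`. Its difference from compound 1 is the two compounds have the same atoms and bonds and differ only in configuration as drawn: 1 of 2 stereo elements differ; a stereocentre at a saturated ring carbon is drawn R in compound 1 and S in compound 4.

For the measured compounds named here, the one measured step that bears on a change of configuration alone is the step from compound 2 to compound 3, which stayed within the scatter even though two stereo elements were inverted there. On that basis the step from compound 1 to compound 4, which inverts one stereo element, is not expected to go beyond the scatter in either direction. The number for compound 4 in this assay is therefore estimated at 15%, with a range of 3% to 35%; the step this estimate means is a number 1 percentage points higher from compound 1 to compound 4 (within the scatter), expected to stay within the scatter.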

Compound 4, a percentage reported as inhibition, at one concentration (the size of the read-out at that concentration, not a potency): 60%
The estimate for compound 4 lay 45 percentage points below the measured number; measured number above the stated range.
By their numbers in this assay, from the lowest: compound 1; then compounds 3 and 2 (each within the scatter of the next); then compound 4.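

In this assay, the inversion of one stereocentre at a saturated ring carbon, with nothing entering or leaving, comes with a number 46 percentage points higher from compound 1 to compound 4 (beyond the scatter). The earlier change of configuration alone, a number 1 percentage points lower from compound 2 to compound 3 (within the scatter), inverted two stereo elements and stayed within the scatter, so that pair gave no sign that drawn configuration could matter on this read-out, whereas this pair shows a large step from a single inversion. The step therefore rests on configuration as drawn and on nothing else in the structure: the fact that compounds 1 and 4 differ only in the configuration as drawn

Still open, going by these compounds, is whether the same inversion would give a step of similar size with an amide or a methyl ester in place of the carboxylic acid, or on the core of compound 2, which carries further hydroxyl groups and no ring double bond. The second stereo element of compound 1 is the same in compound 4, which leaves the effect of inverting it open, and each number here is a reading at one concentration, which gives the size of the inhibition there and not a potency.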